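This account rests on a few compounds, and the source may have more. Where it says the series, first, only, none or still open, it means among the compounds named here.

Among the measured compounds shown here, compound 3 `C[C@H](NC(=O)c1cnnn1Cc1ccc(C(F)(F)F)cc1)c1ccc(C(=O)O)cc1` is one of three compounds measured in a functional assay on CHO cells for antagonist activity at prostaglandin E2 receptor EP4 subtype (Homo sapiens), read by calcium flux, with a stated time of 15 min; a higher number here means a weaker inhibitor, a lower number a stronger inhibitor. For compound 3 the assay reports only a limit, > 10000 nM. Compound 1 `C[C@H](NC(=O)c1nnn(CCOc2ccc(F)cc2)c1C(F)(F)F)c1ccc(C(=O)O)cc1` likewise reaches only a limit, with > 10000 nM. Compound 2 `C[C@H](NC(=O)c1c(C(F)(F)F)nnn1Cc1ccc(C(F)(F)F)cc1)c1ccc(C(=O)O)cc1` gives a number, 225 nM, and differs from compound 3 in one place: trifluoromethyl where compound 3 carries hydrogen on the shared core. That single exchange produced an at least 44-fold higher number from compound 2 to compound 3 (1.64 log units; beyond the scatter), a step at which the limit of > 10000 nM in this assay, at which 2 of the 3 values shown sit, is reached, so its full size is not known beyond its direction. Compound 4 `Cc1nnn(Cc2ccc(C(F)(F)F)cc2)c1C(=O)N[C@@H](C)c1ccc(C(=O)O)cc1` puts a small group back into that same place: methyl in place of hydrogen on an aromatic carbon. Methyl is not trifluoromethyl, and no measured pair shows what methyl alone does here. For the measured compounds named here, still, the only step that bears on this position is the large loss seen when the group was removed, so some gain in potency for compound 4 is expected, short of the whole loss. The step is therefore expected to be an at least 4.0-fold lower number from compound 3 to compound 4 (0.60 log units; beyond the scatter). For compound 4 the estimate is 2500 nM, expected to lie between 400 nM and 10000 nM, with a real chance that compound 4 again reaches only a limit.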

Compound 4, half-maximal inhibitory concentration: > 10000 nM
Compound 4: no number, only a limit; the forecaster's own chance of this, stated with the estimate: 35%; at least 4.0-fold (0.60 log units) between middle value and limit.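

In this assay, exchanging trifluoromethyl for methyl on this aromatic carbon gives an at least 44-fold higher number from compound 2 to compound 4 (1.64 log units; beyond the scatter), so methyl does not keep the potency that compound 2 shows with trifluoromethyl in this place. Among compound 2, compound 3 and compound 4, which differ only in this one place, trifluoromethyl alone gives a measured number, while hydrogen and methyl both end at a limit. The step between hydrogen and methyl cannot be read because compound 3 and compound 4 both stop at the end of the measurable range, so a small effect of methyl could stay hidden there: the limit of > 10000 nM in this assay, at which 3 of the 4 values shown sit.

On these data alone, it remains open whether any group other than trifluoromethyl can restore potency in this place, such as a chlorine atom, an ethyl group, a cyclopropyl group or a nitrile. Also open, as far as these compounds go, is how weak compound 3 and compound 4 really are, and whether they differ from each other at all, which only a reading past the limit could settle.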